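The compounds below may be only part of what the source reports. "The series", "measured", "known", "first", "only" and "open" are said of these compounds alone.

Of the compounds shown here, three from a shared series have been tested in a functional assay on SNU-638 cells (Homo sapiens) for cytotoxicity, read by sulforhodamine B assay, with a stated time of 72 h; a higher number here means a weaker inhibitor, a lower number a stronger inhibitor. Compound 1, `CCS(=O)(=O)Nc1cc(-c2ccc3ncnc(Nc4ccc(F)cc4F)c3c2)cnc1OC`, gives 2050 nM. Compound 2, `CCS(=O)(=O)Nc1cc(-c2ccc3ncnc(Nc4ccc(OCc5ccc(F)cc5)c(Cl)c4)c3c2)cnc1OC`, gives 2360 nM in this assay, and compound 3, `CCCCS(=O)(=O)Nc1cc(-c2ccc3ncnc(Nc4cccc(C(=O)OCC)c4)c3c2)cnc1OC`, gives 25200 nM. Of the three, compound 1 carries the lowest number, yet compound 2 sits within the usual scatter of it, so these two cannot be told apart; compound 3 alone stands apart, with a number beyond the scatter in the weaker direction.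

Compound 4, `CCS(=O)(=O)Nc1cc(-c2ccc3ncnc(Nc4ccc(F)nc4)c3c2)cnc1OC`, has not been measured. It differs from compound 1 in one place: 6-fluoropyridin-3-yl in place of 2,4-difluorophenyl on a nitrogen on an aromatic ring. Going by the values given here, since no measured pair of compounds in this set shows the effect of such a change, the expectation for compound 4 rests only on compound 1 and the size of change that is typical for a swap of this kind. The step from compound 1 to compound 4 in this assay is expected to be small, a 1.5-fold higher number from compound 1 to compound 4 (0.17 log units; within the scatter), possibly not beyond the scatter. Compound 4 is therefore estimated at 3000 nM, within a range from 1200 nM to 8000 nM.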

Compound 4, half-maximal inhibitory concentration: 6520 nM
Beside the measured number, compound 4's estimate is 2.2-fold (0.34 log units) below it, and the stated range covers the measured number.
By their numbers in this assay, from the lowest: compounds 1 and 2 (each within the scatter of the next); then compound 4; then compound 3.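

In this assay, going by these compounds alone, the change on this nitrogen gives a 3.2-fold higher number from compound 1 to compound 4 (0.50 log units; beyond the scatter) and so, unlike the earlier comparisons, isolates a single swap with the rest of compound 1 held fixed. It shows that this position is not indifferent to the group it carries: going from 2,4-difluorophenyl to 6-fluoropyridin-3-yl, a ring of carbon only gives way to a ring with 1 hetero atom and 1 hydrogen-bond acceptor, with 1 fluorine in place of 2, and the number moves modestly in the weaker direction. Nothing measured here accounts for this step.

A single swap changes the ring atom and the fluorine together, so the two cannot be separated. Going by these compounds, how 4-fluorophenyl or unsubstituted pyridin-3-yl on the same nitrogen would read remains open, as does whether a 6-methoxypyridin-3-yl group would follow compound 4.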